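Fluoro for Hydrogen on the Core of Compound 3

This account rests on a few compounds, and the source may have more. Where it says the series, first, only, none or still open, it means among the compounds named here.

Measured in a functional assay on PC-3 cells (Homo sapiens) for cytotoxicity, read by MTT assay, with a stated time of 48 h; a lower number here means a stronger inhibitor, a higher number a weaker inhibitor:
Compound 1, `CC(C)n1c(/C=C2/C(=O)Nc3ccc(Br)cc32)nc2ccccc21`: 10700 nM
Compound 2, `CCn1c(/C=C2/C(=O)Nc3ccc(F)cc32)nc2ccccc21`: only a limit, > 50000 nM
Compound 3, `CC(C)n1c(/C=C2/C(=O)Nc3ccccc32)nc2ccccc21`: 37600 nM

Compound 3 stands at the highest of the two real numbers in this assay. The nearest number belongs to compound 1, and the step from compound 1 to compound 3, a 3.5-fold higher number from compound 1 to compound 3 (0.55 log units; beyond the scatter), shows that replacing the bromo with hydrogen weakened the inhibitor by a modest but real amount. The third value is not a number: for compound 2 the assay reports only (the limit of > 50000 nM in this assay, at which 1 of the 3 values shown sits).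

Compound 4, `CC(C)n1c(/C=C2/C(=O)Nc3ccc(F)cc32)nc2ccccc21`, differs from compound 3 in one place: fluoro in place of hydrogen on an aromatic carbon. Among the measured compounds shown here, only one measured step touches the same position, the step from compound 1 to compound 3 with a 3.5-fold higher number from compound 1 to compound 3 (0.55 log units; beyond the scatter), where the bromo went with the lower number. Against this, compound 2, which also carries fluoro on its core, gives a limit rather than a number in this assay. The evidence therefore pulls both ways, and the expectation is a small step toward a lower number, or none beyond the scatter: a 1.5-fold lower number from compound 3 to compound 4 (0.18 log units; within the scatter). Compound 4 is estimated at 25000 nM, with a range from 8000 nM to 80000 nM.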

Compound 4, half-maximal inhibitory concentration: 20800 nM
Beside the measured number, compound 4's estimate is 1.2-fold (0.08 log units) above it; the range from low to high includes it.
By their numbers in this assay, from the lowest: compounds 1, 4 and 3 (each within the scatter of the next, the first and the last beyond it). At a limit, above all of these: compound 2.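

Fluoro on this aromatic carbon gives a result that sits between the two earlier groups without separating clearly from either: a 1.8-fold lower number from compound 3 to compound 4 (0.26 log units; within the scatter), and a 1.9-fold higher number from compound 1 to compound 4 (0.29 log units; within the scatter). Both steps lie within the scatter, even though the bromo and hydrogen compounds differ beyond it, so these compounds do not show that fluoro behaves like either bromo or hydrogen at this position. Among the compounds shown here, compound 4 also adds something new about the chain on the aromatic nitrogen, where the extra methyl gives an at least 2.4-fold lower number from compound 2 to compound 4 (0.38 log units; beyond the scatter), the first step in this set to change that chain while the core stays the same.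

Compound 2 has only a limit rather than a real number, so this step gives a minimum size and not an exact one: the limit of > 50000 nM in this assay, at which 1 of the 4 values shown sits.

The compounds shown leave open how a chloro or a methoxy group on this aromatic carbon would compare with fluoro and bromo. They also leave open whether a longer chain on the aromatic nitrogen would lower the number further or raise it again.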